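Dropping the trifluoromethyl group from compound 2

The source may report more compounds than this note shows. Statements on the series, on what has been measured and on what is new or still open speak of the compounds shown alone.

In an ADME assay on microsomes from liver (Canis lupus familiaris) for metabolic stability (a lower number here means that the compound disappears faster, a higher number that the compound lasts longer), compound 2 `FC(F)(F)c1ccc(NCCNc2ncc(-c3ncc[nH]3)c(-c3ccc(Cl)cc3Cl)n2)nc1` gives > 0.5 h as a limit of the assay and not a number. In this assay compound 1 `N#Cc1ccc(NCCNc2ncc(-c3ncc[nH]3)c(-c3ccc(Cl)cc3Cl)n2)nc1` likewise gives > 0.5 h as a limit. What the series offers so far is the limit of > 0.5 h in this assay, at which 2 of the 2 values shown sit, and nothing more.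

Compound 3 `Clc1ccc(-c2nc(NCCNc3ccccn3)ncc2-c2ncc[nH]2)c(Cl)c1` is still unmeasured. The change from compound 2 is hydrogen in place of trifluoromethyl on an aromatic carbon and turns 5-(trifluoromethyl)pyridin-2-yl into pyridin-2-yl, with hydrogen in place of trifluoromethyl on an aromatic carbon.

Within the data shown here, one measured step bears on this place: a step that the two limits leave unreadable from compound 1 to compound 2 with trifluoromethyl in place of cyano on an aromatic carbon. That step has no readable size, so no size can be carried over, and no step beyond the usual scatter is expected in this assay in either direction. The estimate amounts to a step that the limit leaves unreadable from compound 2 to compound 3 and remains a rough expectation. Compound 3 is expected at 0.7 h with an estimated range from 0.3 h to 1.6 h. A limit rather than a number may well be the outcome for compound 3.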

Compound 3, half-life: > 0.5 h
Compound 3: no number, only a limit; the forecaster's own chance of this, stated with the estimate: 70%; the middle value does not contradict the limit.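

In this assay compound 3 gives > 0.5 h, a limit of the assay and not a number, so the steps to compound 3 from compound 1 and from compound 2 cannot be read. The compounds shown leave open how long each one actually lasts and whether they differ at all, as the series offers only this: the limit of > 0.5 h in this assay, at which 3 of the 3 values shown sit.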